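Aryl amide series: the step from compound 3 to compound 4

The compounds below may be only part of what the source reports. "The series", "measured", "known", "first", "only" and "open" are said of these compounds alone.

In a functional assay on A549 cells (Homo sapiens) for inhibition, read by CCK-8 assay, with a stated time of 72 h, tested at 1 uM (a higher number here means more inhibition of growth at the concentration tested, a lower number less inhibition of growth), compound 3 `COc1ccc(NC(=O)C2(C(=O)Nc3ccc(Nc4ncc5cc(C(=O)N(C)C)n(C6CCCC6)c5n4)cc3)CC2)cc1` gives 74.4%. Compound 2 `COC(=O)c1ccc(NC(=O)C2(C(=O)Nc3ccc(Nc4ncc5cc(C(=O)N(C)C)n(C6CCCC6)c5n4)cc3)CC2)cc1` gives 77.1%, level with it: a number 2.7 percentage points lower from compound 2 to compound 3 (within the scatter). Compound 1 `Cc1cccc(NC(=O)C2(C(=O)Nc3ccc(Nc4ncc5cc(C(=O)N(C)C)n(C6CCCC6)c5n4)cc3)CC2)c1` gives 35.2%, far lower.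

Compound 4 `CN(C)C(=O)c1cc2cnc(Nc3ccc(NC(=O)C4(C(=O)Nc5ccccc5F)CC4)cc3)nc2n1C1CCCC1` carries 2-fluorophenyl in place of 4-methoxyphenyl on an amide-type nitrogen. Two measured steps change the group on this nitrogen: a number 39.2 percentage points higher from compound 1 to compound 3 (beyond the scatter) and a number 41.9 percentage points higher from compound 1 to compound 2 (beyond the scatter). Both are large, so a swap here can move the number far. Among the compounds with values here, the group entering here has no measured counterpart, so the expectation sits between the two measured levels, with a moderate fall. The expected change is a number 19.4 percentage points lower from compound 3 to compound 4 (beyond the scatter). The estimate for compound 4 is 55%, with an expected range of 30% to 78%.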

Compound 4, percent growth inhibition at one concentration: 79.1%
The estimate for compound 4 lay 24.1 percentage points below the measured number, outside the stated range (above it).
By their numbers in this assay, from the lowest: compound 1; then compounds 3, 2 and 4 (each within the scatter of the next).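

On this amide-type nitrogen, in this assay, 2-fluorophenyl stands level with 4-methoxyphenyl (a number 4.7 percentage points higher from compound 3 to compound 4 (within the scatter)) and with 4-(methoxycarbonyl)phenyl (a number 2 percentage points higher from compound 2 to compound 4 (within the scatter)), so the high level needs neither a methoxy nor a methoxycarbonyl group on the ring. Three different aryl groups now share that level, and 3-methylphenyl alone stands apart (a number 43.9 percentage points higher from compound 1 to compound 4 (beyond the scatter)).

From the compounds shown here alone, whether a cyclohexyl group, or a phenyl ring carrying an amine or a carboxylic acid, keeps this level on the same nitrogen remains open. Nothing available accounts for the low value with 3-methylphenyl.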